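The compounds below may be only part of what the source reports. "The series", "measured", "known", "first", "only" and "open" are said of these compounds alone.

Of the compounds shown here, three that share one core have so far been measured in an ADME assay on MT4 cells (Homo sapiens) for cytotoxicity, read by MTT assay, with a stated time of 96 h; on this read-out higher numbers stand for lower toxicity in this test and lower numbers for higher toxicity in this test. Compound 1 `Fc1ccc(-c2nc3cc(C(F)(F)F)ccc3[nH]2)cc1` gives 22000 nM, the lowest of the three numbers. Compound 3 `O=C(CN1CCCCC1)Nc1ccc(-c2nc3ccccc3[nH]2)cc1` gives 31000 nM, a number that sits within the usual scatter of compound 1, so the two cannot be told apart here. Compound 2 `O=C(CN1CCCCC1)Nc1ccc(-c2nc3cc(Cl)c(Cl)cc3[nH]2)cc1` gives 54000 nM, a gap from compound 1 that lies beyond that scatter. Compound 4 `Oc1ccc(-c2nc3cc(C(F)(F)F)ccc3[nH]2)cc1` is not yet measured in this assay. It differs from compound 1 in one place: hydroxy in place of fluoro on an aromatic carbon. Among the measured compounds shown here, no measured pair shows what this change does in this test, so a 1.1-fold higher number from compound 1 to compound 4 (0.06 log units; within the scatter) is expected to be none beyond the scatter. Compound 4 is therefore estimated at 25000 nM, within a range from 10000 nM to 60000 nM.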

Compound 4, half-maximal cytotoxic concentration: 17000 nM
Estimate against measurement, compound 4: 1.5-fold (0.17 log units) above; measured number inside the range.
By their numbers in this assay, from the lowest: compounds 4, 1, 3 and 2 (each within the scatter of the next, the first and the last beyond it).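

In this assay, hydroxy in place of fluoro, para to a large group, gives a 1.3-fold lower number from compound 1 to compound 4 (0.11 log units; within the scatter). Among the compounds shown here, this is the first direct reading of this change, and it shows that adding a hydrogen-bond donor and acceptor at this position leaves the two compounds indistinguishable in this test. No measured finding is available to explain this result. Going by these compounds, whether an amine, a methoxy group or a carboxylic acid at this position would shift the number beyond the scatter remains open. So does whether this change would give a similar step with other groups on the shared core.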